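This account rests on a few compounds, and the source may have more. Where it says the series, first, only, none or still open, it means among the compounds named here.

Measured so far:
compound 1 `CCOC(=O)c1sc(-c2cccc(NC(=O)c3ccc(F)cc3)c2)nc1Nc1ccc(N2CCN(C)CC2)cc1` — 3.53%
compound 2 `CN1CCN(c2ccc(Nc3nc(-c4cccc(NC(=O)c5ccc(C(F)(F)F)cc5)c4)sc3C(N)=O)cc2)CC1` — 97.8%

In a functional assay on Ramos cells (Homo sapiens) for antiproliferative activity, read by CCK-8 assay, with a stated time of 72 h, tested at 40 uM (on this read-out higher numbers stand for more inhibition at the one concentration tested (going by the name of the read-out) and lower numbers for less inhibition), compound 2 stands highest of the two numbers; the nearest, compound 1, lies lower by a margin beyond the scatter. Among the measured compounds shown here, compound 1 differs from compound 2 in more than one place, so no single step between measured compounds is available.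

Compound 3 `CN1CCN(c2ccc(Nc3nc(-c4cccc(NC(=O)c5ccc(F)cc5)c4)sc3C(N)=O)cc2)CC1` is the unmeasured analogue of compound 2. The change is fluoro in place of trifluoromethyl on an aromatic carbon. For the measured compounds named here, the 4-fluorophenyl that enters is the one carried by compound 1, but compound 1 also differs elsewhere, so the low value of compound 1 cannot be assigned to this swap alone.

With wide uncertainty, the step in this assay is expected to be a number 27.8 percentage points lower from compound 2 to compound 3 (beyond the scatter). Some loss is expected because compound 1 gives only 3.53% while sharing the 4-fluorophenyl, yet most of that gap may belong to the other difference. Compound 3 is expected to give 70%, with a range from 20% to 98%.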

Compound 3, a percentage reported as inhibition, at one concentration (the size of the read-out at that concentration, not a potency): 95.9%
Compound 3: middle estimate off by 25.9 percentage points, on the low side; measured number inside the range.
By their numbers in this assay, from the lowest: compound 1; then compounds 3 and 2 (each within the scatter of the next).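

In this assay, fluoro in place of trifluoromethyl on the aromatic carbon gives a number 1.9 percentage points lower from compound 2 to compound 3 (within the scatter), so at this single concentration the 4-fluorophenyl and 4-(trifluoromethyl)phenyl amides cannot be told apart. Among the compounds shown here, compound 3 also supplies the first comparison with compound 1 that differs in one place: amino in place of ethoxy on a carbonyl carbon gives a number 92.4 percentage points higher from compound 1 to compound 3 (beyond the scatter), which ties the low value of compound 1 to the ethoxy group and not to the 4-fluorophenyl it shares with compound 3. No measurement at hand gives a reason for either step.

Compound 2 and compound 3 both lie near the top of a percentage read-out taken at one concentration, so a difference in potency between them may stay hidden until full concentration-response curves are available. From the compounds shown here alone, it also remains open how the carbonyl position responds to groups other than amino and ethoxy, such as a methylamino group or a hydroxyl giving the carboxylic acid, and whether a methoxy group or plain hydrogen on the aromatic carbon would keep the high value.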